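The compounds below may be only part of what the source reports. "The series", "measured", "known", "first", "only" and "open" are said of these compounds alone.

Measured so far:
compound 1, `CNC(=O)c1cc(C(=O)NC2CC2)cn(CC2CCCOC2)c1=O`, 2
compound 2, `CNC(=O)c1cc(C(=O)NCCO)cn(Cc2ccccc2)c1=O`, 1.9

Working notes on the series. Of the compounds shown here, two have been measured in a physicochemical assay for lipophilicity, at pH 7.4; a lower number here means a more polar compound, a higher number a more lipophilic compound. Compound 1 gives 2, and compound 2 gives 1.9. Going by the values given here, the two values lie within the scatter of each other, so compound 1 is not separated from compound 2 on these numbers; no step between measured compounds that differ in one place is available, and nothing beyond the two values can be said of the pair.

The next compound, compound 3 `CNC(=O)c1cc(C(=O)NC2CC2)cn(Cc2ccccc2F)c1=O`, is to be measured in this assay. It differs from compound 1 in one place: 2-fluorophenyl in place of oxan-3-yl on a saturated chain carbon bound to an aromatic nitrogen. Nothing in the measured pair isolates this change, so the expectation rests on the structures alone. A shift in this assay upward, of moderate size, is expected, meaning the step of a number 0.80 log units higher from compound 1 to compound 3 (beyond the scatter) should be expected to reach beyond the scatter. For compound 3 the estimate in this assay is 2.8, with a range from 2.3 to 3.3.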

Compound 3, distribution coefficient: 3
The estimate for compound 3 lay 0.20 log units below the measured number; the measured number falls inside the stated range.
By their numbers in this assay, from the lowest: compounds 2 and 1 (each within the scatter of the next); then compound 3.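

At this position, on a saturated chain carbon bound to an aromatic nitrogen, the series now has its first step that isolates one place: with the rest of the core of compound 1 unchanged, 2-fluorophenyl in place of oxan-3-yl gives a number 1.00 log units higher from compound 1 to compound 3 (beyond the scatter) in this assay. The position is therefore not silent in this measurement, which the earlier pair could not show, as its two compounds differ in more than one place. The step is a single bundled exchange, in which a six-membered non-aromatic ring with 1 hetero atom and 1 hydrogen-bond acceptor leaves and a six-membered aromatic ring of carbon only, carrying fluorine and with 0 hydrogen-bond acceptors, enters, and no measurement at hand explains the size of the step.

The compounds shown contain no pair that separates the fluorine from the exchange of the ring, so the share of each in the step stays open. From the compounds shown here alone, how this assay would read with a piperidin-4-yl, a carboxylic acid or a longer chain at this place also remains open, as does whether the same exchange would give a similar step with a different amide on the core.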